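Phenyl to pyridin-2-yl on a triazole-bearing diterpenoid scaffold

The source may hold more compounds than are shown below. What is called first, only, known or untested is meant among the compounds shown, and "the series" means these compounds.

The study compares four compounds built on two related cores. Compound 1 `Cc1ccc(S(=O)(=O)Oc2ccc3c(c2C)[C@H](Cn2cc(-c4ccccc4)nn2)[C@@]24CC(=O)[C@@](C)(CC[C@@H]32)C4)cc1` and compound 3 `Cc1ccc(S(=O)(=O)Oc2ccc3c(c2C)[C@H](Cn2cc(-c4ccccn4)nn2)[C@@]24CC(=O)[C@@](C)(CC[C@@H]32)C4)cc1` share one core, while compound 2 `C=C1C(=O)[C@]23C[C@@]1(O)CC[C@H]2c1ccc(O)c(C)c1[C@@H]3Cn1cc(-c2ccccc2)nn1` and the not yet measured compound 4 `C=C1C(=O)[C@]23C[C@@]1(O)CC[C@H]2c1ccc(O)c(C)c1[C@@H]3Cn1cc(-c2ccccn2)nn1` share another; the difference between the two cores is not broken down here. All were, or are to be, examined in a functional assay on HL-60 cells (Homo sapiens) for cytotoxicity, read by MTT assay, with a stated time of 4 days; on this read-out higher numbers stand for weaker inhibition and lower numbers for stronger inhibition.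

In this assay compound 1 reached only a limit, > 20000 nM. Compound 3 likewise gave only a limit, > 20000 nM. The change between them is pyridin-2-yl in place of phenyl on an aromatic carbon, and the step that the two limits leave unreadable from compound 1 to compound 3 cannot be sized, because both values sit at the limit of > 20000 nM in this assay, at which 2 of the 3 values shown sit. Compound 2, by contrast, gave a number in this assay, 750 nM, the only one among the three measured compounds.

Compound 4 carries the same change relative to compound 2: pyridin-2-yl in place of phenyl on an aromatic carbon. The earlier occurrence of this change offers no readable step, so the expectation for compound 4 rests on compound 2 alone and on its value 750 nM. Compound 4 is therefore expected to lie close to its parent, with the estimated step of a 1.3-fold higher number from compound 2 to compound 4 (0.12 log units; within the scatter) from compound 2 to compound 4 kept within what repeated measurements normally scatter. The estimate for compound 4 in this assay is 1000 nM, with a range from 400 nM to 3000 nM.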

Compound 4, half-maximal inhibitory concentration: 1970 nM
Compound 4: the middle estimate sits 2.0-fold (0.29 log units) below what was measured; measured number inside the range.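

In this assay, putting pyridin-2-yl in place of phenyl on the core of compound 2 gives a 2.6-fold higher number from compound 2 to compound 4 (0.42 log units; beyond the scatter), so on this core the change carries a modest cost that lies beyond the scatter. On the core of compound 1 the same change cannot be read, because compound 1 and compound 3 both stand at a limit of the assay rather than at a number: the limit of > 20000 nM in this assay, at which 2 of the 4 values shown sit. The series therefore offers a single readable pair for this change, on a single core, and it does not show whether the size or even the direction of the step carries over from one core to the other.

The compounds shown leave open whether the step seen here belongs to the ring nitrogen of pyridin-2-yl in particular, since pyridin-3-yl, pyridin-4-yl and a phenyl bearing an amine or a carboxylic acid do not appear among them at this place on the five-membered aromatic ring with 3 nitrogen. They also leave open which of the features that separate the two cores decides whether a compound gives a number at all, as no pair shown differs in only one of those features.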